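The source may hold more compounds than are shown below. What is called first, only, known or untested is meant among the compounds shown, and "the series" means these compounds.

Compound 1 `COc1ccc2c(=O)c(/C=C/C(=O)Nc3cccc(C)c3)coc2c1` gives > 100000 nM in a functional assay (QGY7701 cells, Homo sapiens) for inhibition, read by MTT assay, with a stated time of 48 h (on this read-out higher numbers stand for weaker inhibition and lower numbers for stronger inhibition), a limit of the assay rather than a number.
Compound 2 `COc1ccc2c(=O)c(/C=C/C(=O)Nc3cccc(Cl)c3)coc2c1` gives > 100000 nM in this assay, again a limit rather than a number.
Compound 3 `COc1ccc(CNC(=O)/C=C/c2coc3cc(O)ccc3c2=O)cc1` gives 10000 nM in this assay.

For the measured compounds named here, compound 3 thus stands as the only measured number among the three; the other two values sit at the limit of > 100000 nM in this assay, at which 2 of the 3 values shown sit. Compound 4 `O=C(/C=C/c1coc2cc(O)ccc2c1=O)NCc1ccccc1` differs from compound 3 by hydrogen in place of methoxy on an aromatic carbon, on an aromatic carbon of a six-membered aromatic ring of carbon only, para to a large group. Going by the values given here, the one measured step, a step that the two limits leave unreadable from compound 1 to compound 2, concerns a different change, and its size cannot be read. Among the compounds with values here, no measured step bears on removing a methoxy here, so no shift beyond the scatter is expected in this assay. Compound 4 is therefore estimated at 10000 nM, spanning 3000 nM to 40000 nM, a step of no change at the digits printed from compound 3 to compound 4 (within the scatter) that is expected to stay within the scatter.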

Compound 4, half-maximal inhibitory concentration: 63000 nM
Compound 4: middle estimate off by 6.3-fold (0.80 log units), on the low side; measured number above the stated range.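

In this assay, the methoxy at this position matters: the change from 4-methoxyphenyl to phenyl gives a 6.3-fold higher number from compound 3 to compound 4 (0.80 log units; beyond the scatter). This is the first step among the compounds shown that can be read, and it shows that removing this one group moves the number beyond the scatter. Nothing shown gives a cause for this step.

Going by these compounds, it remains open whether an ethoxy group, an amine or a carboxylic acid on this aromatic carbon would match the methoxy, fall to the level of hydrogen or go beyond either.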